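This account rests on a few compounds, and the source may have more. Where it says the series, first, only, none or still open, it means among the compounds named here.

Measured so far:
compound 1, `Cc1ccc(S(=O)(=O)N2CCC(Cl)=CC2CC(C)C)cc1`, 31000 nM in a functional assay on SW1573 cells (Homo sapiens) for antiproliferative activity, read by sulforhodamine B assay, with a stated time of 48 h; a higher number here means a weaker inhibitor of growth, a lower number a stronger inhibitor of growth
compound 2, `Cc1ccc(S(=O)(=O)N2CC=C(Br)CC2)cc1`, > 100000 nM in this assay

Compound 2 reaches only a limit in this assay: its reported value of > 100000 nM is not a number but the edge of what the assay can tell, as noted in the limit of > 100000 nM in this assay, at which 1 of the 2 values shown sits. Of the two values shown it is the one that sits at that edge, while compound 1 gives a plain number in this assay.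

The step from compound 2 leads to compound 3, `Cc1ccc(S(=O)(=O)N2CCC(Br)=CC2CC(C)C)cc1`, which is not yet measured. The change is isobutyl in place of hydrogen on a saturated ring carbon, next to the ring nitrogen and two ring bonds from the ring atom that bears the bromo group. Among the compounds with values here, no measured pair here isolates such a change, so its effect has to be guessed.

Compound 3 is expected to come in at about 35000 nM in this assay, somewhere between 10000 nM and 100000 nM, because compound 1 gives 31000 nM. That would mean an expected step of an at least 2.8-fold lower number from compound 2 to compound 3 (0.45 log units; beyond the scatter), toward stronger growth inhibition, though with a real chance that compound 3 too only reaches the limit.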

Compound 3, concentration for 50% growth inhibition: 26000 nM
Estimate against measurement, compound 3: 1.3-fold (0.13 log units) above; the range from low to high includes it.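

In this assay, within the data shown here, isobutyl on the saturated ring carbon next to the ring nitrogen gives the first readable step at this position, an at least 3.8-fold lower number from compound 2 to compound 3 (0.58 log units; beyond the scatter), so with isobutyl in place of hydrogen the compound gives a plain number rather than a limit. The full size of that step cannot be read, because compound 2 gives only a limit: the limit of > 100000 nM in this assay, at which 1 of the 3 values shown sits. Bromo in place of chloro on the double-bonded ring carbon, with isobutyl present in both compounds, gives a 1.2-fold lower number from compound 1 to compound 3 (0.08 log units; within the scatter), so compound 1 and compound 3 cannot be told apart in this growth read-out, and the choice between these two halogens does not show up here.

From the compounds shown here alone, it remains open whether this step belongs to isobutyl in particular or would also come with a methyl group, a longer chain or an amine on the same saturated ring carbon. Going by these compounds, it is equally open whether a group such as a nitrile in place of the halogen would keep the growth inhibition seen with compound 1 and compound 3.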